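The source may hold more compounds than are shown below. What is called first, only, known or untested is meant among the compounds shown, and "the series" means these compounds.

Measured compounds: compound 1 `CC(C)(N)C(=O)N[C@H](COCc1ccccc1)c1nnnn1CCCCC#N` gives 3120 nM in an assay on isolated protein for displacement of a labelled ligand from growth hormone secretagogue receptor type 1 (Homo sapiens), with a stated time of 1 h; a lower number here means a stronger inhibitor, a higher number a weaker inhibitor; compound 2 `COC(=O)CCCn1nnnc1[C@@H](COCc1ccccc1)NC(=O)C(C)(C)N` gives 2380 nM.

Compound 2 holds the lower of the two numbers, though the step of a 1.3-fold lower number from compound 1 to compound 2 (0.12 log units; within the scatter) lies within the scatter. Compound 3 `CC(C)(N)C(=O)N[C@H](COCc1ccccc1)c1nnnn1CCC(=O)NCCCc1ccccc1` differs from compound 2 in (3-phenylpropyl)carbamoyl in place of (methoxycarbonyl)methyl on a saturated chain carbon, two bonds along the chain from an aromatic nitrogen. Among the measured compounds shown here, the single measured step, a chain-end exchange at a different position, bears only loosely on this larger change and was itself within the scatter. The estimated step is therefore a 1.3-fold lower number from compound 2 to compound 3 (0.12 log units; within the scatter), which does not go beyond the scatter. Compound 3 is estimated at 1800 nM, between 500 nM and 6000 nM.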

Compound 3, inhibition constant: 820 nM
Estimate against measurement, compound 3: 2.2-fold (0.34 log units) above, within the range that was stated.
By their numbers in this assay, from the lowest: compound 3; then compounds 2 and 1 (each within the scatter of the next).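

In this assay, placing (3-phenylpropyl)carbamoyl on a saturated chain carbon, two bonds along the chain from an aromatic nitrogen, gives a 2.9-fold lower number from compound 2 to compound 3 (0.46 log units; beyond the scatter) and a 3.8-fold lower number from compound 1 to compound 3 (0.58 log units; beyond the scatter), both beyond the scatter. The exchange between compound 1 and compound 2 stayed within the scatter, so only compound 3 shows that the number responds to a change in this chain. Nothing measured here explains the gain.

The compounds shown leave open whether the aromatic ring or the amide carries the step. A shorter chain ending in phenyl, or a terminal amine, would bear on this.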